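The source may hold more compounds than are shown below. What is called first, only, known or untested is meant among the compounds shown, and "the series" means these compounds.

Three compounds that share one core were tested in a functional assay on HeLa cells (Homo sapiens) for cytotoxicity, read by MTT assay, with a stated time of 72 h, tested at 100 uM; on this read-out higher numbers stand for more inhibition of growth at the one concentration tested and lower numbers for less inhibition of growth. Compound 1 `N/C(=N\NC(=S)N1CCCCCC1)c1ccccn1` gives 88.7%. Compound 2 `N/C(=N\NC(=S)N1CCOCC1)c1ccccn1` gives 87.2%. Compound 3 `N/C(=N\NC(=S)N1CCCC1)c1ccc(F)cn1` gives 85.4%, a number that lies within the usual scatter of both other values, so the three cannot be told apart on this read-out. Compound 4 `N/C(=N\NC(=S)N1CCOCC1)c1ccc(F)cn1` has not yet been measured; it differs from compound 3 by morpholin-4-yl in place of pyrrolidin-1-yl on a thiocarbonyl carbon. Within the data shown here, no pair of measured compounds isolates this change on its own, but compound 2, which also carries morpholin-4-yl, gives 87.2%. The change is expected to stay within the scatter, a number 1.1 percentage points higher from compound 3 to compound 4 (within the scatter). Compound 4 is expected to give 86.5% in this assay, with a range from 76% to 95%.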

Compound 4, percent growth inhibition at one concentration: 81.2%
Compound 4: the middle estimate sits 5.3 percentage points above what was measured; measured number inside the range.
By their numbers in this assay, from the lowest: compounds 4, 3, 2 and 1 (each within the scatter of the next).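

In this assay, morpholin-4-yl in place of pyrrolidin-1-yl on a thiocarbonyl carbon can now be read on its own, and it gives a number 4.2 percentage points lower from compound 3 to compound 4 (within the scatter) for this single change. Fluoro in place of hydrogen on an aromatic carbon can also be read alone, with a number 6 percentage points lower from compound 2 to compound 4 (within the scatter) for that change. So neither change separates from the scatter, and no measurement on hand offers an explanation for either step.

The compounds shown leave open whether dimethylamino on the thiocarbonyl carbon or chloro on the aromatic carbon would read differently. From the compounds shown here alone, with one concentration tested, how these compounds compare at lower concentrations also stays open.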